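The source may hold more compounds than are shown below. What is called first, only, known or untested is meant among the compounds shown, and "the series" means these compounds.

Working notes on the series. Compound 1 `CC(C)(C)OC[C@@H](N)C(=O)N1CCN(CCCOc2ccc(C(=O)C3CC3)cc2)CC1` is measured in an assay for binding affinity to histamine H2 receptor (Homo sapiens) (a higher number here means a weaker inhibitor, a lower number a stronger inhibitor), at 45700 nM. Among the three numbers in hand it stands second highest: compound 2 `CC(C)N[C@H](C)C(=O)N1CCN(CCCOc2ccc(C(=O)C3CC3)cc2)CC1` gives 50100 nM, and the step of a 1.1-fold higher number from compound 1 to compound 2 (0.04 log units; within the scatter) sits within the scatter, so neither can be ranked against the other. Compound 3 `CCCCCC(=O)c1ccc(OCCCN2CCN(C(=O)[C@H](CC(C)C)NC(=O)OC(C)(C)C)CC2)cc1` differs from compound 1 at several places. In this assay compound 3 gives 3470 nM. Going by the values given here, that number is lower than the one of compound 1 by a margin that lies beyond the scatter; no single change accounts for that gap.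

Compound 4 `CCC[C@@H](N)C(=O)N1CCN(CCCOc2ccc(C(=O)C3CC3)cc2)CC1` is not yet measured. It differs from compound 1 by ethyl in place of tert-butoxy on a saturated chain carbon, two bonds along the chain from an amine nitrogen and a carbonyl carbon. Among the compounds with values here, the only single-point step at hand that touches the same region of the shared core is the step from compound 1 to compound 2, which exchanged the whole 1-amino-2-(tert-butoxy)ethyl group for 1-(isopropylamino)ethyl and stayed within the scatter. A smaller change at that same chain carbon, tert-butoxy to ethyl, is therefore expected to move this assay little, if at all, in either direction. For compound 4 the value is estimated at 40000 nM, with a range from 15000 nM to 100000 nM, meaning an expected step of a 1.1-fold lower number from compound 1 to compound 4 (0.06 log units; within the scatter) from compound 1.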

Compound 4, inhibition constant: 60300 nM
For compound 4 the middle estimate is 1.5-fold (0.18 log units) below the measured one; measured number inside the range.
By their numbers in this assay, from the lowest: compound 3; then compounds 1, 2 and 4 (each within the scatter of the next).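

In this assay, ethyl in place of tert-butoxy on a saturated chain carbon, two bonds along the chain from an amine nitrogen and a carbonyl carbon, gives a 1.3-fold higher number from compound 1 to compound 4 (0.12 log units; within the scatter); the ether oxygen and the hydrogen-bond acceptor counted on tert-butoxy leave, and the heavy atoms of the group fall from five to two, without a step beyond the scatter. The second new step, 1-aminobutyl in place of 1-(isopropylamino)ethyl on a carbonyl carbon, gives a 1.2-fold higher number from compound 2 to compound 4 (0.08 log units; within the scatter), so compounds 1, 2 and 4 cannot be ranked against one another, and this position has now been changed by a single group exchange as well as by the wider exchange of the earlier step, with neither reading beyond the scatter. No measurement at hand offers an explanation for these steps.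

On these data alone, it remains open whether any group on this chain carbon, such as a carboxylic acid, a phenyl ring or a longer chain, would move the number beyond the scatter. As far as these compounds go, it also remains open which of its several differences carries the value of compound 3 at 3470 nM.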